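Fluoro in Place of Chloro: Expected Lipophilicity of Compound 3

This account rests on a few compounds, and the source may have more. Where it says the series, first, only, none or still open, it means among the compounds named here.

Compound 1 `O=[N+]([O-])c1ccc(Oc2ccc(/C=N/NC(=S)Nc3ccccc3)cc2)cc1`: 4.95
Compound 2 `O=[N+]([O-])c1ccc(Oc2ccc(/C=N/NC(=S)Nc3ccc(Cl)cc3)cc2)cc1`: 5.52

In a physicochemical assay for lipophilicity, in phosphate buffer, measured as octanol-water partition, with a stated time of 24 h (a higher number here means a more lipophilic compound, a lower number a more polar compound), compound 1 gives 4.95, and compound 2 gives 5.52. Compound 2 holds the higher of the two numbers, the gap to compound 1 lying beyond the scatter. Among the compounds with values here, the single measured step is a number 0.57 log units higher from compound 1 to compound 2 (beyond the scatter), which came with chloro in place of hydrogen on an aromatic carbon.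

Compound 3 `O=[N+]([O-])c1ccc(Oc2ccc(/C=N/NC(=S)Nc3ccc(F)cc3)cc2)cc1` differs from compound 2 in one place: fluoro in place of chloro on an aromatic carbon. The step bearing on this change is the chloro step, because a number 0.57 log units higher from compound 1 to compound 2 (beyond the scatter) shows what the chloro now leaving added; with fluoro entering instead of hydrogen, compound 3 is expected to give back most, but not all, of that gain. The expected step is a number 0.47 log units lower from compound 2 to compound 3 (beyond the scatter), a downward move beyond the scatter. Compound 3 is therefore estimated at 5.05, with a range from 4.75 to 5.35.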

Compound 3, partition coefficient: 4.89
For compound 3 the middle estimate is 0.16 log units above the measured one; measured number inside the range.
By their numbers in this assay, from the lowest: compounds 3 and 1 (each within the scatter of the next); then compound 2.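

In this assay the exchange of fluoro for chloro at this place, on an aromatic carbon para to a large group, gives a number 0.63 log units lower from compound 2 to compound 3 (beyond the scatter) and removes the whole of the gain seen with chloro, not merely most of it. The comparison with hydrogen, which the chloro step alone could not supply, gives a number 0.06 log units lower from compound 1 to compound 3 (within the scatter) and leaves fluoro and hydrogen indistinguishable here, so that among these three compounds only the chloro of compound 2 stands apart. Nothing given here accounts for this result.

The three compounds leave open how other groups at this place would read, such as a methyl, a methoxy or an amine. They also leave open whether fluoro and hydrogen would read alike elsewhere on the shared core.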